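A Methyl Added to the Phenyl Group of Compound 2

This account rests on a few compounds, and the source may have more. Where it says the series, first, only, none or still open, it means among the compounds named here.

Within the data shown here, compound 2 `COc1ccc2oc(=O)c(C(=O)Nc3ccccc3)cc2c1` gives the lower of the two numbers measured so far in an assay on cells for inhibition of Amine oxidase [flavin-containing] B (Homo sapiens), read by fluorescence and Amplex Red, using microsomes, with a stated time of 15 min (on this read-out lower numbers stand for stronger inhibition and higher numbers for weaker inhibition), namely 5.95 nM. Its nearest neighbour, compound 1 `Cc1ccc2oc(=O)c(C(=O)Nc3ccccc3)cc2c1`, gives 15.3 nM. Among the measured compounds shown here, the only measured step, a 2.6-fold lower number from compound 1 to compound 2 (0.41 log units; beyond the scatter), swaps a group on a different part of the shared core. Compound 3 `COc1ccc2oc(=O)c(C(=O)Nc3ccc(C)cc3)cc2c1` differs from compound 2 by methyl in place of hydrogen on an aromatic carbon. For the measured compounds named here, no measured step touches the phenyl group, so nothing recorded bears directly on this change. Without such a guide, this small addition is not expected to move the number beyond the scatter in either direction. Compound 3 is therefore estimated to give about 6 nM, in a range from 2 nM to 18 nM. That estimate means a step of a 1.0-fold higher number from compound 2 to compound 3 (0.00 log units; within the scatter), expected to stay within the scatter.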

Compound 3, half-maximal inhibitory concentration: 19.4 nM
Estimate against measurement, compound 3: 3.2-fold (0.51 log units) below; the measured number lies above the stated range.
By their numbers in this assay, from the lowest: compound 2; then compounds 1 and 3 (each within the scatter of the next).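

Methyl in place of hydrogen on the phenyl group, para to a large group, gives a 3.3-fold higher number from compound 2 to compound 3 (0.51 log units; beyond the scatter) in this assay. Among these compounds, the earlier step showed only that a swap on the shared core can move the number, whereas this one shows that the phenyl group also responds, and that a single added carbon there is enough to weaken inhibition beyond the scatter. No measurement at hand explains this rise.

From the compounds shown here alone, it remains open whether a fluorine, a chlorine or a methoxy group at the same place would give a similar rise, and whether a methyl elsewhere on that ring would act the same way. Also open, going by these compounds, is whether the same change, phenyl to 4-methylphenyl, would give a step of similar size on compound 1.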